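Replacing the aryl amide with a cyclopentyl amide

The source may hold more compounds than are shown below. What is called first, only, known or untested is meant among the compounds shown, and "the series" means these compounds.

Of the compounds shown here, three on one shared core have been measured in a functional assay on cells for positive allosteric modulation of metabotropic glutamate receptor 5 (Rattus norvegicus), read by calcium flux; on this read-out lower numbers stand for an effect already at smaller amounts and higher numbers for an effect only at larger amounts of compound. Compound 1 `O=C(Nc1cc(-c2ccccc2)nn1-c1ccccc1)c1ccc(OC(F)(F)F)cc1` gives 18 nM, compound 2 `O=C(Nc1cc(-c2ccccc2)nn1-c1ccccc1)c1ccc(C(F)(F)F)cc1` gives 38 nM, and compound 3 `O=C(Nc1cc(-c2ccccc2)nn1-c1ccccc1)c1cc([N+](=O)[O-])cc([N+](=O)[O-])c1` gives 65 nM. Compound 2 sits between the other two: its value and that of compound 3 lie within the usual scatter of each other, whereas compound 1 lies clearly apart from it, the step of a 2.1-fold higher number from compound 1 to compound 2 (0.32 log units; beyond the scatter) being beyond the scatter. Compound 4 `O=C(Nc1cc(-c2ccccc2)nn1-c1ccccc1)C1CCCC1` carries cyclopentyl in place of 4-(trifluoromethyl)phenyl on a carbonyl carbon. Going by the values given here, no measured step bears directly on this change: the only measured step, from trifluoromethoxy to trifluoromethyl, swaps one substituent on an aromatic ring that stays in place, and all three measured compounds keep a six-membered aromatic ring on the carbonyl carbon. Nothing measured here shows what a five-membered non-aromatic ring does at that position. Without a guide, the author expects a step toward a higher number, a 3.9-fold higher number from compound 2 to compound 4 (0.60 log units; beyond the scatter), larger than the aryl-to-aryl step already seen. Compound 4 is therefore estimated at 150 nM, with a range from 40 nM to 600 nM.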

Compound 4, half-maximal effective concentration: 3410 nM
Estimate against measurement, compound 4: 23-fold (1.36 log units) below; the measured number lies above the stated range.
By their numbers in this assay, from the lowest: compound 1; then compounds 2 and 3 (each within the scatter of the next); then compound 4.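

In this assay, cyclopentyl in place of 4-(trifluoromethyl)phenyl on the carbonyl carbon gives a 90-fold higher number from compound 2 to compound 4 (1.95 log units; beyond the scatter), a large step against the modest 2.1-fold higher number from compound 1 to compound 2 (0.32 log units; beyond the scatter), so this position responds far more strongly to replacing the whole group than the one substituent swap had shown. The change alters several things at once, since a six-membered aromatic ring gives way to a five-membered non-aromatic ring and the trifluoromethyl group is lost, and the step alone cannot separate these. No measurement offered here explains the size of the step.

Open, on these data alone, is which of these alterations carries the step. Cyclohexyl would keep the six-membered size without the aromatic ring, while thienyl would keep a five-membered ring that is aromatic.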